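The source may report more compounds than this note shows. Statements on the series, on what has been measured and on what is new or still open speak of the compounds shown alone.

Compound 3 `N=C(N)NCCC[C@H](NC(=O)CN(c1ncnc2c1ncn2C1CCCCO1)C1CC1)C(=O)OCc1ccccc1` stands highest of the three measured compounds in a functional assay on the whole organism (Tail, strain ICR) with Mus musculus as the target, in the tail flick test, with a stated time of 90 min, at a dose of 25 umol/kg by the oral route (a lower number here means a weaker effect, a higher number a stronger effect of the compound at the dose given), with 61.6%. Compound 1 `NC(=O)CC[C@H](NC(=O)CN(c1ncnc2c1ncn2C1CCCCO1)C1CC1)C(=O)OCc1ccccc1` gives 37.8% in this assay, and compound 2 `O=C(CN(c1ncnc2c1ncn2C1CCCCO1)C1CC1)NCC(=O)OCc1ccccc1` gives 25.9%. The relevant steps are a number 23.8 percentage points higher from compound 1 to compound 3 (beyond the scatter) and a number 35.7 percentage points higher from compound 2 to compound 3 (beyond the scatter), both of which show that the group now leaving carried the highest number. Compound 4 `CSCC[C@H](NC(=O)CN(c1ncnc2c1ncn2C1CCCCO1)C1CC1)C(=O)OCc1ccccc1` differs from compound 3 by a group of 2 heavy atoms (1 carbon, 1 sulfur; no ring) in place of a group of 5 heavy atoms (2 carbon, 3 nitrogen; no ring), on a saturated chain carbon, three bonds along the chain from an amide-type nitrogen and a carbonyl carbon. Since the steps toward compound 3 from compound 1 and compound 2 were modest to large, the return to a smaller group is expected to cost a modest step, as a number 26.6 percentage points lower from compound 3 to compound 4 (beyond the scatter). The value of compound 4 in this assay is therefore estimated at 35%, within 18% to 52%.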

Compound 4, a percentage reported as activity, at one dose (the size of the read-out at that dose, not a potency): 42.7%
Compound 4: middle estimate off by 7.7 percentage points, on the low side, within the range that was stated.
By their numbers in this assay, from the lowest: compound 2; then compounds 1 and 4 (each within the scatter of the next); then compound 3.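

In this assay, methylsulfanyl at this place does not hold the level of the group of 5 heavy atoms it replaces, a number 18.9 percentage points lower from compound 3 to compound 4 (beyond the scatter). The 2-(methylsulfanyl)ethyl chain still improves on hydrogen, a number 16.8 percentage points higher from compound 2 to compound 4 (beyond the scatter), so a chain without nitrogen also raises the number. Methylsulfanyl and carbamoyl cannot be told apart, a number 4.9 percentage points higher from compound 1 to compound 4 (within the scatter), and only the group of 5 heavy atoms stands clear of both. Going by these compounds, whether a simple amine or a carboxylic acid at the chain end would match that group remains open. Nothing available explains these differences.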